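Chlorine for Fluorine on the Benzyl Arm

The source may report more compounds than this note shows. Statements on the series, on what has been measured and on what is new or still open speak of the compounds shown alone.

Compound 2 `O=c1ccoc2cc(OCc3cn(Cc4ccc(F)cc4)nn3)ccc12` and compound 1 `Cc1ccccc1Cn1cc(COc2ccc3c(=O)ccoc3c2)nn1` share one core and differ only in the group on a saturated chain carbon bound to an aromatic nitrogen. In a functional assay on MDA-MB-231 cells (Homo sapiens) for cytotoxicity, read by MTT assay, with a stated time of 48 h (a lower number here means a stronger inhibitor, a higher number a weaker inhibitor), compound 1 gives > 100000 nM, which is a limit of the assay and not a number. In this assay compound 2 gives > 100000 nM, again a limit. The step that the two limits leave unreadable from compound 1 to compound 2 therefore cannot be read, because both values sit at the limit of > 100000 nM in this assay, at which 2 of the 2 values shown sit. Compound 2 thus stands at the limit of this assay, with no number to place it more closely.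

Compound 3 `O=c1ccoc2cc(OCc3cn(Cc4cccc(Cl)c4)nn3)ccc12` has not yet been measured. It differs from compound 2 by 3-chlorophenyl in place of 4-fluorophenyl on a saturated chain carbon bound to an aromatic nitrogen. Within the data shown here, the only measured step, from compound 1 to compound 2, is unreadable, so no measured step bears on this change with a readable size. Compound 3 is expected to stay near the same limit, with the step of a number no higher from compound 2 to compound 3 (the limit leaves the size open) estimated as no change beyond the scatter. For compound 3 the estimate in this assay is 100000 nM, with a range from 30000 nM to 300000 nM.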

Compound 3, half-maximal inhibitory concentration: > 100000 nM
Compound 3: a limit, no number (the forecaster's own chance of this, stated with the estimate: 85%); the middle value lies on the limit itself.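

In this assay compound 3 gives > 100000 nM, which is a limit of the assay and not a number. The steps linking compound 3 to compound 1 and compound 2 therefore cannot be read. The compounds shown leave open how weak each one really is, and whether any group on this shared core would bring a readable value.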